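The source may report more compounds than this note shows. Statements on the series, on what has been measured and on what is new or still open speak of the compounds shown alone.

Working notes on the series.

In a functional assay on MCF7 cells (Homo sapiens) for cytotoxicity, read by MTT assay, with a stated time of 72 h (a higher number here means a weaker inhibitor of growth, a lower number a stronger inhibitor of growth), compound 1 `CCCCCSc1nc(NCc2ccc([Se]C)cc2)c2ccccc2n1` gives 75200 nM. Compound 2 `CSc1nc(NCc2ccc([Se]C)cc2)c2ccccc2n1` reaches only the limit of this assay, > 100000 nM, so no number is known for it. Compound 3 `Nc1nc([SeH])nc2ncccc12` likewise stops at the limit of this assay, > 100000 nM. Compound 2 therefore stands at the weak end of the values shown, as described by the limit of > 100000 nM in this assay, at which 2 of the 3 values shown sit.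

The step to compound 4 `CSc1nc(NCc2ccccc2)c2ccccc2n1` is a hydrogen atom in place of a group of 2 heavy atoms (1 carbon, 1 selenium; no ring), on an aromatic carbon.

Of the measured steps only an at least 1.3-fold higher number from compound 1 to compound 2 (0.12 log units; that floor lies within the scatter) touches the same scaffold, and it concerns a different group on a different part of the molecule; it sits within the scatter and gives no direction for a change on the aromatic carbon. Nothing measured removes the methylselanyl group.

With compound 2 already at the limit, compound 4 is expected to remain near that limit, with an estimated step that the limit leaves unreadable from compound 2 to compound 4. The estimate for compound 4 in this assay is 150000 nM, within a range of 40000 nM to 600000 nM, and most likely reported only as a limit.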

Compound 4, concentration for total growth inhibition: 82800 nM
Compound 4: middle estimate off by 1.8-fold (0.26 log units), on the high side; measured number inside the range.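

In this assay, this is the first change shown at the aromatic carbon para to a large group, where hydrogen replaces the methylselanyl group: an at least 1.2-fold lower number from compound 2 to compound 4 (0.08 log units; that floor lies within the scatter). Compound 4 carries no selenium yet gives a readable value, 82800 nM, so in this series the methylselanyl group is not required for growth inhibition at this level. The size of the true step stays unknown because compound 2 is recorded only as a limit: the limit of > 100000 nM in this assay, at which 2 of the 4 values shown sit.

Open, going by these compounds, is whether another group on this aromatic carbon, such as an amine, a carboxylic acid or a longer chain, would shift the number beyond the scatter. Also open, on these data alone, is how the butyl extension on the saturated chain carbon bound to sulfur behaves once the methylselanyl group is gone.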